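The compounds below may be only part of what the source reports. "The series", "measured", "known", "first", "only" and "open" are said of these compounds alone.

Working notes on the series.

Three compounds of this set carry a measurement. Compound 1 `Cc1nc(N(C)C(=O)NC(=O)c2c(F)cccc2F)sc1C(=O)N/N=C/c1ccc(C(F)(F)F)cc1` is tested in a functional assay on HeLa cells (Homo sapiens) for inhibition, read by MTT assay, with a stated time of 72 h (a lower number here means a stronger inhibitor, a higher number a weaker inhibitor), and gives 40.6 ug/mL. Compound 2 `CN(C(=O)NC(=O)c1ccc([N+](=O)[O-])cc1)c1nc(C(F)(F)F)c(C(=O)N/N=C/c2cccc(C(F)(F)F)c2)s1` gives 4.12 ug/mL in this assay, and compound 3 `CN(C(=O)NC(=O)c1ccc(Cl)cc1Cl)c1nc(C(F)(F)F)c(C(=O)N/N=C/c2ccc(C(F)(F)F)cc2)s1` gives 7.99 ug/mL. Compound 1 therefore stands with the highest number of the three, beyond the scatter from both compound 3 and compound 2; compounds 2 and 3 differ from compound 1 in more than one place, so no single step can be read out of those gaps.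

Compound 4 `Cc1nc(N(C)C(=O)NC(=O)c2c(F)cccc2F)sc1C(=O)N/N=C/c1ccccc1C(F)(F)F` has the same atoms as compound 1 but joined differently: 2-(trifluoromethyl)phenyl in place of 4-(trifluoromethyl)phenyl on a carbon with a double bond to nitrogen. Going by the values given here, the two compounds share everything else, and no measured pair in the set isolates a change of this kind, so there is nothing to anchor the direction.

The expectation is a step from compound 1 to compound 4 of a 1.2-fold lower number from compound 1 to compound 4 (0.06 log units; within the scatter), that is, nothing clearly beyond the scatter in either direction. Compound 4 is accordingly estimated at 35 ug/mL, with a range from 12 ug/mL to 100 ug/mL.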

Compound 4, half-maximal inhibitory concentration: 6.51 ug/mL
Compound 4: middle estimate off by 5.4-fold (0.73 log units), on the high side, and the stated range ends above it.
By their numbers in this assay, from the lowest: compounds 2, 4 and 3 (each within the scatter of the next); then compound 1.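

Going by these compounds alone, the exchange of 4-(trifluoromethyl)phenyl for 2-(trifluoromethyl)phenyl on a carbon with a double bond to nitrogen is the first change that can be read alone, and in this assay it gives a 6.2-fold lower number from compound 1 to compound 4 (0.79 log units; beyond the scatter). The two groups have the same atoms and the same counts, so this place in the series responds to how the group is joined, not only to which atoms it contains. Nothing measured here accounts for the size or direction of this step.

As far as these compounds go, it remains open whether the same step holds on the core of compound 3, which differs from compound 1 in more than one place. Also open, from the compounds shown here alone, is whether a methoxy group or a carboxylic acid in place of trifluoromethyl on this phenyl ring would keep the lower number of compound 4.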